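Methyl ester to free acid in a cytotoxic series

This account rests on a few compounds, and the source may have more. Where it says the series, first, only, none or still open, it means among the compounds named here.

Compound 1 `C=CCC/C=C\C=C/CCCCCCCC[C@@H]1CC[C@@H]([C@@H]2CC[C@@H](CC(=O)OC)OO2)O1`: 0.1 ug/mL
Compound 2 `C=CCCC/C=C/C=C\CCCCCCCC[C@H]1CC[C@H]([C@@H]2CC[C@@H](CC(=O)O)OO2)O1`: 0.1 ug/mL
Compound 3 `C=CCCC/C=C/C=C\CCCCCCCC[C@H]1CC[C@H]([C@@H]2CC[C@@H](CC(=O)OC)OO2)O1`: 0.1 ug/mL

In a functional assay on MEL28 cells (Homo sapiens) for cytotoxicity (on this read-out higher numbers stand for weaker inhibition and lower numbers for stronger inhibition), compound 1 gives 0.1 ug/mL, and compound 2 and compound 3 stand level with it within the scatter. Compound 4 `C=CCC/C=C\C=C/CCCCCCCC[C@@H]1CC[C@@H]([C@@H]2CC[C@@H](CC(=O)O)OO2)O1` differs from compound 1 by hydrogen in place of methyl on an oxygen next to a carbonyl group. Within the data shown here, one measured step bears on this change, the reverse one, no change at the digits printed from compound 2 to compound 3 (within the scatter), which lies within the scatter; there the methyl ester and the free acid gave the same reading. On that basis no movement beyond the scatter is expected, and the step from compound 1 to compound 4 is estimated as no change at the digits printed from compound 1 to compound 4 (within the scatter) in this assay. Compound 4 is thus expected to give 0.1 ug/mL in this assay, with a likely range from 0.05 ug/mL to 0.25 ug/mL.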

Compound 4, half-maximal inhibitory concentration: 0.1 ug/mL
For compound 4 middle estimate and measured number coincide at the digits printed; low and high end bracket the measured number.
By their numbers in this assay, from the lowest: compounds 1, 2, 3 and 4 (each within the scatter of the next).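

In this assay, putting hydrogen in place of methyl on the oxygen next to a carbonyl group gives no change at the digits printed from compound 1 to compound 4 (within the scatter). The earlier compounds shown here showed this change on one core only, and it now reads the same on a second core, so the methyl ester and the free acid stand level on both: the same change on two cores in this assay, no change at the digits printed (within the scatter) from compound 2 to compound 3 and no change at the digits printed (within the scatter) from compound 4 to compound 1, 1.0-fold (0.00 log units) apart, within the scatter of two such steps. The compounds shown leave open whether an ethyl ester or a primary amide in place of the methoxycarbonyl group would also stand level with them.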